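The compounds below may be only part of what the source reports. "The series", "measured", "known", "first", "only" and "open" are said of these compounds alone.

Measured so far in a functional assay on A549 cells (Homo sapiens) for antiproliferative activity, read by MTT assay, with a stated time of 48 h; on this read-out lower numbers stand for stronger inhibition and higher numbers for weaker inhibition:
compound 1 `COc1ccc(-c2nn(-c3ccccc3)cc2C(Nc2nc3ccccc3s2)c2c(O)ccc3ccccc23)cc1`, 26200 nM
compound 2 `O=[N+]([O-])c1ccc(-c2nn(-c3ccccc3)cc2C(Nc2nc3ccccc3s2)c2c(O)ccc3ccccc23)cc1`, 41300 nM
compound 3 `O=[N+]([O-])c1cccc(-c2nn(-c3ccccc3)cc2C(Nc2nc3ccc(Cl)cc3s2)c2c(O)ccc3ccccc23)c1`, 42500 nM

Compound 1 and compound 2 share one core; the change between them is methoxy in place of nitro on an aromatic carbon, and the step of a 1.6-fold lower number from compound 2 to compound 1 (0.20 log units; within the scatter). Compound 3 carries a second core; the difference between the two cores is not broken down here. Compound 4 `COc1cccc(-c2nn(-c3ccccc3)cc2C(Nc2nc3ccc(Cl)cc3s2)c2c(O)ccc3ccccc23)c1` is not yet measured; it differs from compound 3 by methoxy in place of nitro on an aromatic carbon. This is the same kind of change as that from compound 2 to compound 1, but the place differs: para to a large group there, meta to a large group here. For compound 4 a step of about a 1.4-fold lower number from compound 3 to compound 4 (0.15 log units; within the scatter) is expected, because the earlier step of a 1.6-fold lower number from compound 2 to compound 1 (0.20 log units; within the scatter) stayed within the scatter. Compound 4 is estimated at 30000 nM in this assay, most likely between 15000 nM and 60000 nM.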

Compound 4, half-maximal inhibitory concentration: 49800 nM
Beside the measured number, compound 4's estimate is 1.7-fold (0.22 log units) below it; the measured number falls inside the stated range.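

In this assay, methoxy in place of nitro gives a 1.2-fold higher number from compound 3 to compound 4 (0.07 log units; within the scatter), so on the core of compound 3 this change again stays within the scatter. The steps on the two cores do not differ: the same change on two cores in this assay, a 1.6-fold lower number (0.20 log units; within the scatter) from compound 2 to compound 1 and a 1.2-fold higher number (0.07 log units; within the scatter) from compound 3 to compound 4, 1.8-fold (0.27 log units) apart, within the scatter of two such steps. Among these compounds, this shows only that the change produced no step beyond the scatter on either core; it gives no direction that carries over, and because the place also differs (para to a large group on one core, meta to a large group on the other), any effect of core cannot be separated from one of place.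

As far as these compounds go, whether an amine or a carboxylic acid in this place would give a step beyond the scatter remains open. Also open, from the compounds shown here alone, is whether the two places would give matching steps on a single core.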